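Shifting the quinolinyl attachment on the carbonyl carbon

This account rests on a few compounds, and the source may have more. Where it says the series, first, only, none or still open, it means among the compounds named here.

Measured compounds:
Compound 1, `N=C(N)NCCC[C@@H](NC(=O)c1cnc2ccccc2c1)C(=O)NCc1ccc(C(F)(F)F)cc1`, gives 96 nM in a functional assay on HEK293 cells for antagonist activity at melanin-concentrating hormone receptor 1 (Homo sapiens); on this read-out higher numbers stand for weaker inhibition and lower numbers for stronger inhibition.
Compound 2, `N=C(N)NCCC[C@@H](NC(=O)c1ccnc2ccccc12)C(=O)NCc1ccc(C(F)(F)F)cc1`, gives 1030 nM in this assay.

Compound 1 holds the lowest of the two numbers shown. Among the measured compounds shown here, the one measured step, an 11-fold higher number from compound 1 to compound 2 (1.03 log units; beyond the scatter), exchanged one quinolinyl attachment for another on the carbonyl carbon and was large.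

Compound 3, `N=C(N)NCCC[C@@H](NC(=O)c1ccc2ccccc2n1)C(=O)NCc1ccc(C(F)(F)F)cc1`, has not yet been measured. Against compound 1 its change is quinolin-2-yl in place of quinolin-3-yl on a carbonyl carbon.

For the measured compounds named here, only the step from compound 1 to compound 2 bears on this change: it also swapped the quinolinyl attachment on the same carbonyl carbon, and it moved the number well beyond the scatter. No measurement shows what quinolin-2-yl does, so the direction for compound 3 is uncertain; a step beyond the scatter seems more likely than none, and the measured precedent points towards a higher number. Compound 3 is therefore expected to give about 400 nM in this assay, with a range from 100 nM to 2000 nM. This estimate amounts to a 4.2-fold higher number from compound 1 to compound 3 (0.62 log units; beyond the scatter).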

Compound 3, half-maximal inhibitory concentration: 904 nM
Compound 3: the middle estimate sits 2.3-fold (0.35 log units) below what was measured; low and high end bracket the measured number.
By their numbers in this assay, from the lowest: compound 1; then compounds 3 and 2 (each within the scatter of the next).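

In this assay, the change to quinolin-2-yl gives a 9.4-fold higher number from compound 1 to compound 3 (0.97 log units; beyond the scatter) and thus a second attachment on the carbonyl carbon that departs from quinolin-3-yl, so the advantage of compound 1 no longer rests on a single comparison. The step of a 1.1-fold lower number from compound 2 to compound 3 (0.06 log units; within the scatter) shows that quinolin-2-yl and quinolin-4-yl cannot be told apart on this read-out, which leaves quinolin-3-yl alone among the three attachments shown and compound 1 the most potent of the three. No available evidence explains why the point of attachment matters so much at this place.

The compounds shown leave open whether any other attachment on this carbonyl carbon, such as quinolin-6-yl or quinolin-7-yl, would stay with quinolin-3-yl or fall with the other two. They also leave open whether naphthalen-2-yl, with its rings of carbon only, or an isoquinolinyl group would match compound 1, and whether the same gap between attachments would persist if the 4-(trifluoromethyl)benzyl amide were replaced by a plain benzyl amide.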